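A few compounds are considered here, and "the series" means these few. Any claim that something is new, unique, unknown or untested is made for them only; others in the source may bear on it.

Compound 1 `CC(=O)N1CCN(c2cccc3c2ccn3S(=O)(=O)c2ccccc2)CC1` gives 714 nM in an assay on isolated protein for displacement of a labelled ligand from 5-hydroxytryptamine receptor 6 (Homo sapiens), read by scintillation counting, with a stated time of 1 h; a lower number here means a stronger inhibitor, a higher number a weaker inhibitor. Compound 2 `O=S(=O)(c1ccccc1)n1ccc2c(N3CCCCC3)cccc21` gives 128 nM. Compound 3 `CN(C)c1cccc2c1ccn2S(=O)(=O)c1ccccc1` gives 65 nM.

Compound 3 sits at the low end of the three numbers, though its difference from compound 2 is within the scatter; its step from compound 1, an 11-fold lower number from compound 1 to compound 3 (1.04 log units; beyond the scatter), is beyond it. Compound 4 `O=S(=O)(c1ccccc1)n1ccc2c(-c3ccccc3)cccc21` is the next neighbour: phenyl in place of dimethylamino on an aromatic carbon. Within the data shown here, no measured step swaps an amine for a ring of carbon only; the steps that come nearest, a 2.0-fold lower number from compound 2 to compound 3 (0.29 log units; within the scatter) and a 5.6-fold lower number from compound 1 to compound 2 (0.75 log units; beyond the scatter), each exchange one amine for another at the same carbon and are a loose guide at best. The expected step is a 2.3-fold higher number from compound 3 to compound 4 (0.36 log units; beyond the scatter), a modest rise held with little confidence. Compound 4 is therefore expected at 150 nM, within 40 nM to 600 nM.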

Compound 4, inhibition constant: 162 nM
Estimate against measurement, compound 4: 1.1-fold (0.03 log units) below; the range from low to high includes it.
By their numbers in this assay, from the lowest: compounds 3, 2 and 4 (each within the scatter of the next, the first and the last beyond it); then compound 1.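

A nitrogen on this aromatic carbon is not needed for a number in this range: phenyl, a ring of carbon only with no hydrogen-bond acceptor, is within the scatter of piperidin-1-yl (a 1.3-fold higher number from compound 2 to compound 4 (0.10 log units; within the scatter)) and gives a lower number than 4-acetylpiperazin-1-yl (a 4.4-fold lower number from compound 1 to compound 4 (0.64 log units; beyond the scatter)). Replacing dimethylamino costs only a modest rise (a 2.5-fold higher number from compound 3 to compound 4 (0.40 log units; beyond the scatter)). Nothing available explains these steps. Going by these compounds, whether a pyridine ring or a phenyl carrying methoxy would hold or lower the number remains open. So does the effect of a small group such as methyl at this carbon.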